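The compounds below may be only part of what the source reports. "The series", "measured", "known", "first", "only" and "open" are said of these compounds alone.

Measured in an ADME assay on microsomes from liver (Homo sapiens) for metabolic stability; on this read-out lower numbers stand for slow clearance and higher numbers for fast clearance:
Compound 1 `Cc1ccc2[nH]c(C(=O)N[C@H]3CCN(S(=O)(=O)c4ccccc4Cl)C[C@@H]3C(=O)N[C@H]3CCCN(C)C3)cc2c1`: 244 mL.min-1.g-1
Compound 2 `O=C(N[C@H]1CN(S(=O)(=O)c2ccccc2)C[C@@H]1C(=O)N[C@H]1CCCNC1)c1cn(C2CC2)cn1`: < 3 mL.min-1.g-1

The entry for compound 2 is a limit and not a number: the limit of < 3 mL.min-1.g-1 in this assay, at which 1 of the 2 values shown sits.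

Compound 3 `O=C(N[C@H]1CN(S(=O)(=O)c2ccccc2)C[C@@H]1C(=O)N[C@H]1CCCNC1)c1cc(-c2ccc(Cl)cc2)on1` has not yet been measured. It keeps the rest of compound 2 and exchanges one group: 5-(4-chlorophenyl)-1,2-oxazol-3-yl in place of 1-cyclopropyl-1H-imidazol-4-yl on a carbonyl carbon. Among the measured compounds shown here, no measured pair shows a change of this kind, so any forecast rests on little. For the measured compounds named here, the only high number available is that of compound 1, at 244 mL.min-1.g-1, which is a loose guide. A rise beyond the usual scatter is expected, with the larger group entering, and the estimated step is an at least 6.6-fold higher number from compound 2 to compound 3 (0.82 log units; beyond the scatter). For compound 3 the estimate is 20 mL.min-1.g-1, with an expected range from 5 mL.min-1.g-1 to 80 mL.min-1.g-1.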

Compound 3, intrinsic clearance in microsomes: < 3 mL.min-1.g-1
Compound 3: only a limit was reported (the forecaster's own chance of this, stated with the estimate: 10%); middle value at least 6.6-fold (0.82 log units) away from the limit.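

In this assay, compound 2 and compound 3 each give a limit and not a number, so no step between them can be read: the limit of < 3 mL.min-1.g-1 in this assay, at which 2 of the 3 values shown sit.

The compounds shown leave open whether exchanging 1-cyclopropyl-1H-imidazol-4-yl for 5-(4-chlorophenyl)-1,2-oxazol-3-yl changes clearance at all.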